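From Trifluoromethyl to Nitro: Expecting a Small Step

The compounds below may be only part of what the source reports. "The series", "measured", "known", "first", "only" and "open" are said of these compounds alone.

Measured so far in a functional assay on Bel-7402 cells (Homo sapiens) for cytotoxicity, read by MTT assay, with a stated time of 72 h; on this read-out higher numbers stand for weaker inhibition and lower numbers for stronger inhibition:
- compound 1 `C=C1C(=O)[C@@]23C(=O)OC[C@]4(C(=O)CCC(C)(C)[C@H]4C=O)[C@@H]2CC[C@@H]1[C@H]3OC(=O)CC`: 1650 nM
- compound 2 `C=C1C(=O)[C@@]23C(=O)OC[C@]4(C(=O)CCC(C)(C)[C@H]4C=O)[C@@H]2CC[C@@H]1[C@H]3OC(=O)c1ccc(OC)cc1`: 2800 nM
- compound 3 `C=C1C(=O)[C@@]23C(=O)OC[C@]4(C(=O)CCC(C)(C)[C@H]4C=O)[C@@H]2CC[C@@H]1[C@H]3OC(=O)c1ccc(C(F)(F)F)cc1`: 3990 nM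

In this assay, compound 3 gives 3990 nM. Two measured steps place it: a 1.4-fold higher number from compound 2 to compound 3 (0.15 log units; within the scatter) and a 2.4-fold higher number from compound 1 to compound 3 (0.38 log units; beyond the scatter). Its number therefore cannot be separated from the first of those neighbours, while it sits modestly above the second.

The next member is compound 4 `C=C1C(=O)[C@@]23C(=O)OC[C@]4(C(=O)CCC(C)(C)[C@H]4C=O)[C@@H]2CC[C@@H]1[C@H]3OC(=O)c1ccc([N+](=O)[O-])cc1`, with nitro in place of trifluoromethyl on an aromatic carbon, para to a large group: nitro in place of trifluoromethyl on an aromatic carbon.

For the measured compounds named here, no measured step makes this exact exchange. The closest evidence is the change at the same aromatic carbon, a 1.4-fold higher number from compound 2 to compound 3 (0.15 log units; within the scatter), which stayed within the scatter. The two changes on the carbonyl carbon, a 1.7-fold higher number from compound 1 to compound 2 (0.23 log units; within the scatter) and a 2.4-fold higher number from compound 1 to compound 3 (0.38 log units; beyond the scatter), were also small, and only the latter passed beyond the scatter. With just three compounds this is thin support, but it gives no reason to expect a large move. No step beyond the scatter is expected in this assay, and no direction can be argued with confidence.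

The estimate amounts to a 1.1-fold lower number from compound 3 to compound 4 (0.06 log units; within the scatter). Compound 4 is expected at 3500 nM, with an estimated range from 1900 nM to 6500 nM.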

Compound 4, half-maximal inhibitory concentration: 3300 nM
The estimate for compound 4 lay 1.1-fold (0.03 log units) above the measured number; low and high end bracket the measured number.
By their numbers in this assay, from the lowest: compounds 1, 2, 4 and 3 (each within the scatter of the next, the first and the last beyond it).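

In this assay, nitro in place of trifluoromethyl on the aromatic carbon, para to a large group, gives a 1.2-fold lower number from compound 3 to compound 4 (0.08 log units; within the scatter), and nitro in place of methoxy on that same carbon gives a 1.2-fold higher number from compound 2 to compound 4 (0.07 log units; within the scatter). With compound 4 added, methoxy, trifluoromethyl and nitro all stand within the scatter of one another, so none of these three groups can be told apart at this position in this assay. On the carbonyl carbon, 4-nitrophenyl in place of ethyl gives a 2.0-fold higher number from compound 1 to compound 4 (0.30 log units; within the scatter), which leaves compound 3 as the only one of the three aromatic compounds beyond the scatter from compound 1, and nothing shown here accounts for any of these numbers.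

The compounds shown leave open whether an amine or a carboxylic acid on that aromatic carbon would carry the number beyond the scatter of these three groups. They also leave open whether a longer chain in place of ethyl on the carbonyl carbon would give a number that can be separated from that of compound 1.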